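The source may report more compounds than this note shows. Statements on the series, on what has been measured and on what is new or still open speak of the compounds shown alone.

Compound 1 `O=C(Nc1cccc(-n2cc(-c3ccncc3)c(-c3cc(O)cc(Cl)c3)n2)c1)Nc1ccc(Cl)c(C(F)(F)F)c1` serves as the anchor of the set; in a functional assay on SF-295 cells (Homo sapiens) for inhibition, read by sulforhodamine B assay, with a stated time of 48 h, tested at 10 uM (a higher number here means a weaker effect of the compound at the concentration tested, a lower number a stronger effect), compound 1 gives 14.3%. Compound 2 `COc1cc(Cl)cc(-c2nn(-c3cccc(NC(=O)Nc4ccc(Cl)c(C(F)(F)F)c4)c3)cc2-c2ccncc2)c1` differs from it by a single change, (methyl in place of hydrogen on an oxygen on an aromatic ring), and in this assay compound 2 gives -7.48%; the step is a number 21.8 percentage points lower from compound 1 to compound 2 (beyond the scatter).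

Compound 3 `O=C(Nc1cccc(-n2cc(-c3ccncc3)c(-c3cc(O)cc(Cl)c3)n2)c1)c1cc(C(F)(F)F)cc(C(F)(F)F)c1` carries a different core; the difference between the cores of compound 1 and compound 3 is not broken down here. In this assay compound 3 gives 15%, a number that sits with compound 1 within the scatter.

Compound 4 `COc1cc(Cl)cc(-c2nn(-c3cccc(NC(=O)c4cc(C(F)(F)F)cc(C(F)(F)F)c4)c3)cc2-c2ccncc2)c1` stands to compound 3 as compound 2 stands to compound 1: the change is methyl in place of hydrogen on an oxygen on an aromatic ring, the same change at an identically described place. For the measured compounds named here, the only precedent for it is a number 21.8 percentage points lower from compound 1 to compound 2 (beyond the scatter), so the step of a number 19 percentage points lower from compound 3 to compound 4 (beyond the scatter) is expected to be of similar size and direction, with wide bounds since a single precedent on another core is all that supports it. Compound 4 is expected near -4%, within -22% to 14%.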

Compound 4, a percentage reported as activity, at one concentration (the size of the read-out at that concentration, not a potency): 42.1%
Estimate against measurement, compound 4: 46.1 percentage points below, and the stated range ends below it.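

In this assay, the change from 3-chloro-5-hydroxyphenyl to 3-chloro-5-methoxyphenyl on the core of compound 3 gives a number 27.1 percentage points higher from compound 3 to compound 4 (beyond the scatter), a weaker effect at the concentration tested, whereas the same change on the core of compound 1 gave a stronger one. The change therefore does not carry a single direction from one core to the other, and the two steps clearly differ: the same change on two cores in this assay, a number 21.8 percentage points lower (beyond the scatter) from compound 1 to compound 2 and a number 27.1 percentage points higher (beyond the scatter) from compound 3 to compound 4, 48.9 percentage points apart, beyond the scatter of two such steps. This rests on one pair per core, read at one concentration in one cell line, and it does not show which part of the difference between the cores goes with the reversal, or why the direction reverses.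

The compounds shown leave open whether the reversal is particular to hydroxy and methoxy or extends to other groups at that place, such as an ethoxy group or an amine. On these data alone, whether either core would give a consistent direction across such a set also remains open.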